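Hydroxy for Methoxy on the Ester Chain of Compound 2

The source may hold more compounds than are shown below. What is called first, only, known or untested is meant among the compounds shown, and "the series" means these compounds.

In an ADME assay on HEK293 cells (Homo sapiens) for cytotoxicity, read by luminescence, with a stated time of 72 h (on this read-out higher numbers stand for an effect only at larger amounts of compound and lower numbers for an effect already at smaller amounts), compound 1 (`COc1cc2[nH]c(-c3cccc(Oc4ccccc4)c3)c(C(=O)NCCN3CCCC3)c(=O)c2cc1F`) gives > 22000 nM as a limit of the assay. Compound 2 (`COCCOC(=O)c1c(-c2cccc(Oc3ccccc3)c2)[nH]c2cc(OC)c(F)cc2c1=O`) gives > 22000 nM as a limit too. Compound 3 (`COc1cc2[nH]c(-c3cccc(Oc4ccccc4)c3)c(C(=O)OCCO)c(=O)c2cc1F`) has 2-hydroxyethyl in place of 2-methoxyethyl, with hydrogen in place of methyl on an oxygen on a saturated carbon. Within the data shown here, the one measured step is a step that the two limits leave unreadable from compound 1 to compound 2 and has no readable size. With only the limit of > 22000 nM in this assay, at which 2 of the 2 values shown sit, as evidence, no step beyond the scatter is expected from compound 2 in this assay here. The expected change is a number no higher from compound 2 to compound 3 (the limit leaves the size open) in size. Compound 3 is estimated at 22000 nM (range 10000 nM to 44000 nM) and will probably again be reported as a limit.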

Compound 3, half-maximal effective concentration: > 22000 nM
Compound 3: no number, only a limit (the forecaster's own chance of this, stated with the estimate: 80%); the middle value sits exactly at the limit.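

Among these compounds, compound 1, compound 2 and compound 3 all stand only at a limit of this assay, so no step among them can be read. The compounds shown leave open whether their chains differ at all in this assay.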